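This account rests on a few compounds, and the source may have more. Where it says the series, first, only, none or still open, it means among the compounds named here.

Measured compounds in the series:

- compound 1 `COc1ccc(N2C(=O)COc3ccc(-c4cnc(Cl)c(NS(=O)(=O)c5ccc(F)cc5)c4)cc32)cc1`: 30100 nM
- compound 3 `Cc1ccc(N2C(=O)COc3ccc(-c4cnc(Cl)c(NS(=O)(=O)c5ccc(F)cc5)c4)cc32)cc1`: 34300 nM
- compound 2 `Cc1ccc(N2C(=O)COc3ccc(-c4cnc5ccccc5c4)cc32)cc1`: reported only as a limit, > 40000 nM

All three were run in a functional assay on HCT-116 cells (Homo sapiens) for antiproliferative activity, read by MTT assay, with a stated time of 72 h; a lower number here means a stronger inhibitor, a higher number a weaker inhibitor. Compound 3 gives 34300 nM. Compound 1 carries methoxy in place of methyl on an aromatic carbon on the same core and gives 30100 nM. The step between them, a 1.1-fold lower number from compound 3 to compound 1 (0.06 log units; within the scatter), is within the usual scatter, so the methoxy in place of methyl on this aromatic carbon is not seen to move the read-out on that core.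

Compound 2 returns no number, only a limit of this assay, > 40000 nM. Its value sits at the limit of > 40000 nM in this assay, at which 1 of the 3 values shown sits. The difference between the core of compound 2 and the core of compound 3 is not broken down here.

Compound 4 `COc1ccc(N2C(=O)COc3ccc(-c4cnc5ccccc5c4)cc32)cc1` has not yet been measured in this assay. It differs from compound 2 by methoxy in place of methyl on an aromatic carbon, the same change made from compound 3 to compound 1, in the same place. Since that change gave a step within the scatter, the expected step for compound 4 is a step that the limit leaves unreadable from compound 2 to compound 4, resting on a 1.1-fold lower number from compound 3 to compound 1 (0.06 log units; within the scatter) and on the limit for compound 2, > 40000 nM. It is therefore expected that compound 4 will again most likely return only a limit rather than a number. Should a number be obtained, the estimate for compound 4 is 45000 nM. The lower end of that estimate for compound 4 is 25000 nM. The upper end of that estimate for compound 4 is 100000 nM.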

Compound 4, half-maximal inhibitory concentration: > 40000 nM
Compound 4 gave a limit, no number; the forecaster's own chance of this, stated with the estimate: 70%; the middle value is on the limit's open side.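

In this assay compound 2 and compound 4 both return a limit and not a number, so no new step can be read between them: the limit of > 40000 nM in this assay, at which 2 of the 4 values shown sit.

The compounds shown leave open whether methoxy in place of methyl moves the read-out at all on the core of compound 2, and how far that core stands from the core of compound 3.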